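From Furan to Thiophene on a Shared Core

A few compounds are considered here, and "the series" means these few. Any claim that something is new, unique, unknown or untested is made for them only; others in the source may bear on it.

Compound 3 `CC(CNCc1ccoc1)Oc1cccc2ccc(N)nc12` gives 10 nM in an assay on cells with melanin-concentrating hormone receptor 1 (Homo sapiens) as the target, read by radioligand binding (a higher number here means a weaker inhibitor, a lower number a stronger inhibitor), the lowest of three numbers. Compound 1 `CC(CN1CCCC1)Oc1cccc2ccc(N)nc12` gives 70 nM, and compound 2 `CC(CNCc1ccccc1)Oc1cccc2ccc(N)nc12` gives 100 nM; the steps of a 7.0-fold lower number from compound 1 to compound 3 (0.85 log units; beyond the scatter) and a 10-fold lower number from compound 2 to compound 3 (1.00 log units; beyond the scatter) both lie beyond the scatter. Compound 4 `CC(CNCc1ccsc1)Oc1cccc2ccc(N)nc12` differs from compound 3 in one place: thiophen-3-yl in place of furan-3-yl on a saturated chain carbon bound to an amine nitrogen. For the measured compounds named here, only the step from phenyl to furan-3-yl bears on this swap, and it showed the five-membered aromatic ring with one hetero atom favoured over phenyl by a modest margin; no measured step tells furan from thiophene. A small rise in the number, within or just beyond the scatter, is therefore expected for compound 4, a 1.8-fold higher number from compound 3 to compound 4 (0.26 log units; within the scatter). Compound 4 is estimated at 18 nM, between 6 nM and 55 nM.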

Compound 4, half-maximal inhibitory concentration: 10 nM
Estimate against measurement, compound 4: 1.8-fold (0.26 log units) above; the range from low to high includes it.
By their numbers in this assay, from the lowest: compounds 3 and 4 (each within the scatter of the next); then compounds 1 and 2 (each within the scatter of the next).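

The step of no change at the digits printed from compound 3 to compound 4 (within the scatter) shows that, on this saturated chain carbon bound to an amine nitrogen, thiophen-3-yl and furan-3-yl cannot be told apart in this assay. The advantage over phenyl therefore extends to a second five-membered aromatic ring, as a 10-fold lower number from compound 2 to compound 4 (1.00 log units; beyond the scatter) shows, and the advantage over the pyrrolidin-1-yl compound also remains, as a 7.0-fold lower number from compound 1 to compound 4 (0.85 log units; beyond the scatter) shows. Nothing available explains why these two rings give matching numbers. Still open, going by these compounds, is whether pyridin-3-yl or thiazol-5-yl at this place would keep the number as low as these two rings do.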